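The source may report more compounds than this note shows. Statements on the series, on what has been measured and on what is new or still open speak of the compounds shown alone.

Compound 1 `COc1cc2cc(Oc3ccc(NC(=O)Nc4cccc(C(F)(F)F)c4)cc3)c(C)nc2cc1OC`: 15800 nM
Compound 2 `COc1cc2cc(Oc3ccc(NC(=O)Nc4ccc(Cl)c(C(F)(F)F)c4)cc3)c(C)nc2cc1OC`: 5110 nM

Among the compounds with values here, in a functional assay on DU-145 cells (Homo sapiens) for inhibition, read by sulforhodamine B assay, with a stated time of 48 h (a lower number here means a stronger inhibitor of growth, a higher number a weaker inhibitor of growth), compound 2 gives the lower of the two numbers; the one measured step, a 3.1-fold lower number from compound 1 to compound 2 (0.49 log units; beyond the scatter), adds a chloro group. Compound 3 `COc1cc2cc(Oc3ccc(NC(=O)Nc4ccc(Cl)c(Cl)c4)cc3)c(C)nc2cc1OC` differs from compound 2 by chloro in place of trifluoromethyl on an aromatic carbon. Within the data shown here, no measured step exchanges these two groups, so that step bears on the change only indirectly, and the expectation is uncertain. The step is expected to be a 1.3-fold higher number from compound 2 to compound 3 (0.10 log units; within the scatter), not beyond the scatter. For compound 3 the estimate is 6500 nM, with a range from 2500 nM to 16000 nM.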

Compound 3, concentration for total growth inhibition: 17100 nM
The estimate for compound 3 lay 2.6-fold (0.42 log units) below the measured number, outside the stated range (above it).
By their numbers in this assay, from the lowest: compound 2; then compounds 1 and 3 (each within the scatter of the next).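

In this assay, this place on the ring does not treat chloro and trifluoromethyl alike: exchanging them gives a 3.3-fold higher number from compound 2 to compound 3 (0.52 log units; beyond the scatter). The 3,4-dichlorophenyl group and the 3-(trifluoromethyl)phenyl group stand level, with a 1.1-fold higher number from compound 1 to compound 3 (0.03 log units; within the scatter), so among these compounds the benefit of the added chloro appears only when trifluoromethyl stays on the ring. Nothing available here explains this difference. As far as these compounds go, it remains open how a methyl, a methoxy or a nitrile would behave at this place, and whether a single chloro there would match compound 3.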